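A Second Trifluoromethyl on a Benzamide Core

This account rests on a few compounds, and the source may have more. Where it says the series, first, only, none or still open, it means among the compounds named here.

Compound 1 `COc1cc(NC(=O)c2cccc(C(F)(F)F)c2)ccc1NS(=O)(=O)C(F)(F)F` and compound 2 `COc1cc(NC(=O)c2cc(C(F)(F)F)cc(C(F)(F)F)c2)ccc1NS(=O)(=O)C(F)(F)F` share one core and differ in a single place: trifluoromethyl in place of hydrogen on an aromatic carbon. In an ADME assay on RAW264.7 cells (Mus musculus) for cytotoxicity, read by MTT assay, with a stated time of 48 h (on this read-out lower numbers stand for stronger inhibition and higher numbers for weaker inhibition), compound 1 gives 75200 nM. Compound 2 reaches only a limit of this assay, > 250000 nM. The step is therefore an at least 3.3-fold higher number from compound 1 to compound 2 (0.52 log units; beyond the scatter), and its true size is open at the upper end.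

Compound 3 `CS(=O)(=O)Nc1ccc(NC(=O)c2cccc(C(F)(F)F)c2)cc1F` carries a different core; the difference between the two cores is not broken down here. In this assay compound 3 gives 32300 nM, the lowest of the two numbers reported so far.

Compound 4 `CS(=O)(=O)Nc1ccc(NC(=O)c2cc(C(F)(F)F)cc(C(F)(F)F)c2)cc1F` has not yet been measured. It differs from compound 3 by the same change, (trifluoromethyl in place of hydrogen on an aromatic carbon). Since compound 2 sits at the limit of > 250000 nM in this assay, at which 1 of the 3 values shown sits, the earlier step gives only a lower bound for what this change does. Compound 4 is expected to show a 3.7-fold higher number from compound 3 to compound 4 (0.57 log units; beyond the scatter), a step of at least similar size to the earlier one. Compound 4 is estimated at 120000 nM, most likely between 50000 nM and 250000 nM.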

Compound 4, half-maximal inhibitory concentration: 125000 nM
Compound 4: middle estimate off by 1.0-fold (0.02 log units), on the low side; the measured number falls inside the stated range.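

On the core of compound 3, the second trifluoromethyl gives a 3.9-fold higher number from compound 3 to compound 4 (0.59 log units; beyond the scatter) in this assay, so the number moves in the same direction on both cores shown, although two cores say nothing about any third. Set beside the earlier step, the two readings compare as follows: the same change on two cores in this assay, an at least 3.3-fold higher number (0.52 log units; beyond the scatter) from compound 1 to compound 2 and a 3.9-fold higher number (0.59 log units; beyond the scatter) from compound 3 to compound 4; the limit leaves it open whether they differ. From the compounds shown here alone, the size of the step on the core of compound 1 stays unknown, since compound 2 is a limit of the assay and not a number: the limit of > 250000 nM in this assay, at which 1 of the 4 values shown sits.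

The compounds shown leave open whether a different group on that aromatic carbon, such as a chlorine, a nitrile or a carboxylic acid, would shift the number in this assay as trifluoromethyl does. Also open, going by these compounds, is whether the step would hold on a core carrying an amine or a longer chain in place of the groups seen here.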